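The compounds below may be only part of what the source reports. "The series", "measured", "known", "first", "only" and "open" are said of these compounds alone.

Measured so far:
compound 1 `Cc1nc2ccccc2c(=O)n1/N=C/c1ccc(Oc2ccc(Br)cc2)cc1` — 4.64
compound 2 `Cc1nc2ccccc2c(=O)n1/N=C/c1ccc(Oc2ccc3ccccc3c2)cc1` — 5.22
compound 3 `Cc1nc2ccccc2c(=O)n1/N=C/c1ccc(Oc2ccccc2)cc1` — 4.01

In a physicochemical assay for lipophilicity, in phosphate buffer, measured as octanol-water partition (on this read-out lower numbers stand for lower lipophilicity and higher numbers for higher lipophilicity), compound 2 gives the highest of the three numbers: its nearest neighbour is compound 1, which is lower by a number 0.58 log units higher from compound 1 to compound 2 (beyond the scatter), and the furthest is compound 3, lower by a number 1.21 log units lower from compound 2 to compound 3 (beyond the scatter). The unmeasured compound 4 `O=c1c2ccccc2nc(-c2ccccc2)n1/N=C/c1ccc(Oc2ccc3ccccc3c2)cc1` is reached from compound 2 by a single change: phenyl in place of methyl on an aromatic carbon. Going by the values given here, no measured step makes this same exchange, so none bears on it directly. What the measured steps do show is that the larger aryl group goes with the higher number in this assay, as seen in a number 0.58 log units higher from compound 1 to compound 2 (beyond the scatter) and in a number 1.21 log units lower from compound 2 to compound 3 (beyond the scatter), whereas removing bromo lowered it (a number 0.63 log units lower from compound 1 to compound 3 (beyond the scatter)). Adding a phenyl in place of methyl is an exchange of the same kind, so a rise beyond the scatter is expected, estimated at a number 1.28 log units higher from compound 2 to compound 4 (beyond the scatter). For compound 4 this assay is therefore expected to give about 6.5, within a range from 5.8 to 7.2.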

Compound 4, partition coefficient: 6.53
The estimate for compound 4 lay 0.03 log units below the measured number; low and high end bracket the measured number.
By their numbers in this assay, from the lowest: compound 3; then compound 1; then compound 2; then compound 4.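

Going by these compounds alone, the earlier compounds differed only in the aryl group on the oxygen, so compound 4 gives the first reading of a change elsewhere in the molecule, on an aromatic carbon between two ring nitrogen atoms of the shared core. In this assay, phenyl in place of methyl at this position gives a large step (a number 1.31 log units higher from compound 2 to compound 4 (beyond the scatter)), which shows that the read-out responds to a change here as well as to changes in the aryl group on the oxygen. Nothing at hand accounts for the size of this step.

The compounds shown leave open what an amine, a cyclohexyl group or a carboxylic acid would do at this position. They also leave open whether phenyl in place of methyl gives a similar step when the group on the oxygen is 4-bromophenyl or phenyl rather than naphthalen-2-yl.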